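Swapping the Chain-End Group on a Shared Core

The source may hold more compounds than are shown below. What is called first, only, known or untested is meant among the compounds shown, and "the series" means these compounds.

- compound 1 `CCCCCC/C=C/C[C@H]1C[C@@H]([C@@H](O)c2ccccc2)CO[C@@H]1c1ccccc1` gives 7400 nM as a number
- compound 2 `O[C@@H](c1ccccc1)[C@H]1CO[C@H](c2ccccc2)[C@@H](C/C=C/c2cccnc2)C1` gives > 100000 nM as a limit, not a number

Both results come from a functional assay on HeLa cells (Homo sapiens) for cytotoxicity, read by WST assay, with a stated time of 48 h (on this read-out lower numbers stand for stronger inhibition and higher numbers for weaker inhibition), and describe compounds with a shared core. For compound 2 the result > 100000 nM is a limit of this assay and not a number. Compound 3 `O=[N+]([O-])c1ccccc1/C=C/C[C@H]1C[C@@H]([C@@H](O)c2ccccc2)CO[C@@H]1c1ccccc1` keeps that core and changes one group: 2-nitrophenyl in place of pyridin-3-yl on a double-bonded chain carbon bound to a double-bonded chain carbon, which means 2-nitrophenyl in place of pyridin-3-yl on a double-bonded chain carbon bound to a double-bonded chain carbon.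

For the measured compounds named here, only one measured step bears on this change. It is an at least 13-fold higher number from compound 1 to compound 2 (1.13 log units; beyond the scatter), a large step at this same place, so the group here can matter strongly. That step does not involve 2-nitrophenyl, so the forecast is loose. Compound 3 is expected to move some of the way back towards compound 1, which gives 7400 nM as its value. Another limit remains possible for compound 3. The expected step is an at least 4.0-fold lower number from compound 2 to compound 3 (0.60 log units; beyond the scatter) and it points to a lower number. For compound 3 the estimate is 25000 nM, with an expected range from 7000 nM to 90000 nM in this test.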

Compound 3, half-maximal inhibitory concentration: 11800 nM
Compound 3: the middle estimate sits 2.1-fold (0.33 log units) above what was measured; the measured number falls inside the stated range.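

Compound 2 alone could suggest that an aromatic ring at the chain end, on a double-bonded chain carbon bound to a double-bonded chain carbon, removes the effect on these cells. Compound 3 rules out that reading: it also carries a six-membered aromatic ring there, yet the change from pyridin-3-yl to 2-nitrophenyl gives an at least 8.4-fold lower number from compound 2 to compound 3 (0.92 log units; beyond the scatter). The comparison with the hexyl group gives a 1.6-fold higher number from compound 1 to compound 3 (0.20 log units; within the scatter), so a flexible chain and this substituted ring cannot be told apart in this assay, and the position tolerates two very different end groups. Compound 2 is the only one of the three that ends at a limit of the test and not at a number: the limit of > 100000 nM in this assay, at which 1 of the 3 values shown sits.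

These compounds cannot show whether the gap between compound 2 and compound 3 follows from losing the ring nitrogen of pyridin-3-yl or from gaining the nitro group, and a plain phenyl at this place would separate those two changes. How much the length of the chain matters also stays open, since hexyl is the only chain shown and a shorter one such as butyl would test it.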